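The source may hold more compounds than are shown below. What is called first, only, known or untested is meant among the compounds shown, and "the series" means these compounds.

Measured so far in a functional assay on U-87MG ATCC cells (Homo sapiens) for cytotoxicity, read by MTT assay, with a stated time of 48 h (on this read-out lower numbers stand for stronger inhibition and higher numbers for weaker inhibition), of two compounds:

- compound 1 `CC(=NNC(=S)Nc1ccccc1)c1ccccn1` gives 1.4 nM here
- compound 2 `C/C(=N\NC(=S)Nc1ccc([N+](=O)[O-])cc1)c1ccccn1` gives 160 nM here

Compound 2 stands highest of the two at 160 nM and compound 1 sits far lower at 1.4 nM with a gap well beyond the usual scatter of repeated measurements.

Compound 3 `CC(=NNC(=S)Nc1ccc([N+](=O)[O-])cc1)c1ccccn1` has not yet been measured. Its difference from compound 2 is the two compounds have the same atoms and bonds; at least one stereo element is drawn with a configuration in one of them and without one in the other: 1 of 1 stereo elements differ; a double bond is drawn E in compound 2 and without a configuration in compound 3 and nothing more: the two compounds have the same atoms and bonds, and a double bond is drawn E in compound 2 and without a configuration in compound 3.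

No measured pair shows a difference of this kind in this assay so the expectation rests on compound 2 alone. Since compound 3 shares all its atoms and bonds with compound 2 at 160 nM no step beyond the scatter is expected in either direction. The expected 1.1-fold lower number from compound 2 to compound 3 (0.03 log units; within the scatter) is estimated to stay within the scatter. In this assay compound 3 is estimated at 150 nM with an expected range from 50 nM to 450 nM once it is measured.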

Compound 3, half-maximal inhibitory concentration: 160 nM
Compound 3: the middle estimate sits 1.1-fold (0.03 log units) below what was measured; measured number inside the range.
By their numbers in this assay, from the lowest: compound 1; then compounds 2 and 3 (each within the scatter of the next).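

In this assay, whether the double bond is drawn with a configuration makes no visible difference: the numbers show no change at the digits printed from compound 2 to compound 3 (within the scatter). The two entries are separated by one thing only: the fact that one of compounds 2 and 3 is drawn with a defined configuration and the other without, at the place where they differ. The nitro change can now also be read on its own, with no difference in drawn configuration on top of it, which the earlier pair could not offer: nitro in place of hydrogen on an aromatic carbon gives a 110-fold higher number from compound 1 to compound 3 (2.06 log units; beyond the scatter).

The compounds shown carry only hydrogen or nitro on that aromatic carbon, so it stays open whether this large step is specific to nitro or would come with other groups there, such as a methoxy group, an amine or a chlorine atom. Going by these compounds, it also stays open whether the other configuration of the double bond, drawn and tested as a single defined form, would match these numbers, as a drawing without a configuration does not say which form or forms the tested sample of compound 3 held.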